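The compounds below may be only part of what the source reports. "The series", "measured", "known", "first", "only" and "open" are said of these compounds alone.

Working notes on the oxime-ether acid series, at the step from compound 1 to compound 4.

Compound 1, `C/C(=N\OCC(=O)O)c1ccccc1`, is the parent of the set. In a functional assay on the whole organism for inhibition, with Rattus norvegicus as the target, read by paw edema, with stated times of 1 h and 3 h, at a dose of 50 mg/kg by the oral route (on this read-out lower numbers stand for less inhibition and higher numbers for more inhibition at the one dose given (going by the name of the read-out)), compound 1 gives < 20%, which is a limit of the assay and not a number. Two ring-substituted analogues stand beside it. Compound 2, `C/C(=N\OCC(=O)O)c1cccc(Cl)c1`, gives 20% in this assay. Compound 3, `C/C(=N\OCC(=O)O)c1ccc(C(C)(C)C)cc1`, gives < 20%, again a limit rather than a number. The measured steps from compound 1 are therefore a number no lower from compound 1 to compound 2 (the limit leaves the size open) and a step that the two limits leave unreadable from compound 1 to compound 3; neither shows a change that can be sized, and both sit at or next to the limit of < 20% in this assay, at which 2 of the 3 values shown sit. Nothing in these three values rises clearly above the scatter of the read-out.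

The compound still to be measured is compound 4, `C/C(=N\OCC(=O)O)c1ccc(C#N)cc1`. Its difference from compound 1 is cyano in place of hydrogen on an aromatic carbon. Both measured substitutions on the aromatic ring of compound 1 left the read-out at or near the limit, so a step of no readable size is the only expectation that the data support for compound 4. Compound 4 is accordingly estimated at 15%, within 5% to 28%, and the expected step is a step that the limit leaves unreadable from compound 1 to compound 4; a limit rather than a number is the most probable outcome.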

Compound 4, a percentage reported as inhibition, in the whole organism at one dose (the size of the read-out at that dose, not a potency): < 20%
Compound 4: only a limit was reported (the forecaster's own chance of this, stated with the estimate: 60%); the middle value is on the limit's open side.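

In this assay compound 4 gives < 20%, a limit and not a number. No step can be read from compound 1 or compound 3 to compound 4, because these values all sit at one limit: the limit of < 20% in this assay, at which 3 of the 4 values shown sit.

The compounds shown leave open whether any ring substituent on the core of compound 1 truly changes the read-out in this assay.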